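Hepatocyte clearance: 3-aminoazetidin-1-yl in place of 3-hydroxycyclobutyl

The compounds below may be only part of what the source reports. "The series", "measured", "known", "first", "only" and "open" are said of these compounds alone.

Measured so far in an ADME assay on cells (Hepatocyte, Homo sapiens) for metabolic stability; a lower number here means slower removal, a higher number faster removal of the compound:
compound 1 `Nc1nc(-n2cc(C(=O)O)c(=O)c3cc(F)c([C@H]4C[C@H](O)C4)c(Cl)c32)c(F)cc1F`: compound 1 gives 6.8 uL/min
compound 2 `Nc1nc(-n2cc(C(=O)O)c(=O)c3cc(F)c([C@H]4C[C@@H](O)C4)c(Cl)c32)c(F)cc1F`: compound 2 gives 9.2 uL/min

Compound 2 stands with compound 1 inside the scatter of this assay; the step of a 1.4-fold higher number from compound 1 to compound 2 (0.13 log units; within the scatter) is small, and this follows from the fact that compounds 1 and 2 differ only in the configuration as drawn, the two being mirror images with the same atoms and bonds.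

Compound 3 `Nc1nc(-n2cc(C(=O)O)c(=O)c3cc(F)c(N4CC(N)C4)c(Cl)c32)c(F)cc1F` is not yet measured. Against compound 2 it differs in one place: 3-aminoazetidin-1-yl in place of 3-hydroxycyclobutyl on an aromatic carbon. Among the compounds with values here, the only measured step concerns a change of configuration alone and does not touch the group at this position, so no measured step bears on the present change. Compound 2 is the only anchor, and the step of a 1.2-fold lower number from compound 2 to compound 3 (0.09 log units; within the scatter) is expected to be small, with a wide range in either direction. Compound 3 is therefore estimated at 7.5 uL/min in this assay, with a range from 3 uL/min to 18 uL/min.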

Compound 3, intrinsic clearance in a liver preparation (reported as CLH), per the amount of preparation that the assay uses in the Hepatocyte assay: 3 uL/min
Compound 3: middle estimate off by 2.5-fold (0.40 log units), on the high side; the range from low to high includes it.
By their numbers in the Hepatocyte assay, from the lowest: compound 3; then compounds 1 and 2 (each within the scatter of the next).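

In the Hepatocyte assay this position, on an aromatic carbon ortho to a chloro group and a fluoro group, proves responsive to the group placed there: 3-aminoazetidin-1-yl in place of 3-hydroxycyclobutyl gives a 3.1-fold lower number from compound 2 to compound 3 (0.49 log units; beyond the scatter) and a 2.3-fold lower number from compound 1 to compound 3 (0.36 log units; beyond the scatter). Both forms of the 3-hydroxycyclobutyl group thus lead to a lower number, whereas the earlier pair, which differs only in configuration, showed no step beyond the scatter. The same exchange also registers in a physicochemical assay for acid dissociation, where compound 2 gives 4.96 and compound 3 gives 5.33, with a number 0.37 log units higher from compound 2 to compound 3 (beyond the scatter).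

The exchange alters the ring and its substituent at once, so the compounds shown do not separate the two; a 3-hydroxyazetidin-1-yl or a 3-aminocyclobutyl group at this position would. Going by these compounds, whether the steps in the two assays are connected also remains open.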